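A few compounds are considered here, and "the series" means these few. Any claim that something is new, unique, unknown or untested is made for them only; others in the source may bear on it.

Compound 3 `CCCCCN1CCc2nc(C)c(C(OC(C)(C)C)C(=O)O)c(-c3ccc(C)cc3)c2C1` carries a pentyl group on an amine nitrogen in a ring. In an ADME assay on MT2 cells (Homo sapiens) for cytotoxicity, read by XTT assay, with a stated time of 4 days (a higher number here means that more compound is tolerated, a lower number that less compound is tolerated), compound 3 gives a limit rather than a number, > 40000 nM. Two close relatives were measured alongside it. Compound 1 `Cc1ccc(-c2c3c(nc(C)c2C(OC(C)(C)C)C(=O)O)CCN(S(C)(=O)=O)C3)cc1`, with methylsulfonyl in that place, also gives only a limit, > 40000 nM. Compound 2 `Cc1ccc(-c2c3c(nc(C)c2C(OC(C)(C)C)C(=O)O)CCN(CCCC2CCCC2)C3)cc1`, with 3-cyclopentylpropyl there, likewise gives only a limit, > 40000 nM. Because all three sit at the limit of > 40000 nM in this assay, at which 3 of the 3 values shown sit, the steps a step that the two limits leave unreadable from compound 1 to compound 3, a step that the two limits leave unreadable from compound 1 to compound 2 and a step that the two limits leave unreadable from compound 2 to compound 3 cannot be read: the three groups on that nitrogen differ widely, yet none reveals a measurable difference in tolerated concentration. Compound 4 `COC(=O)N1CCc2nc(C)c(C(OC(C)(C)C)C(=O)O)c(-c3ccc(C)cc3)c2C1` is the next variation: methoxycarbonyl in place of pentyl on an amine nitrogen in a ring. No measured step bears on this change in a readable way, so the expectation rests only on the observation that every group tried on this nitrogen among these three compounds left the result at the limit. Compound 4 is therefore expected to give 40000 nM, with a range from 20000 nM to 100000 nM. The expected step is a number no higher from compound 3 to compound 4 (the limit leaves the size open), which amounts to no change beyond the scatter.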

Compound 4, half-maximal cytotoxic concentration: > 40000 nM
Compound 4: a limit, no number (the forecaster's own chance of this, stated with the estimate: 85%); the middle value lies on the limit itself.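

Compound 4 gives only a limit in this assay, as do compound 1, compound 2 and compound 3, so its steps to all three cannot be read: the limit of > 40000 nM in this assay, at which 4 of the 4 values shown sit. The compounds shown leave open whether any group on that ring nitrogen changes the tolerated concentration.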